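The source may report more compounds than this note shows. Statements on the series, on what has been measured and on what is new or still open speak of the compounds shown alone.

Measured so far:
compound 1 `O=C(Nc1cccc(-n2cc(-c3ccncc3)c(-c3ccc(Cl)c(O)c3)n2)c1)Nc1cccc(C(F)(F)F)c1` — 2120 nM
compound 2 `COc1cc(-c2nn(-c3cccc(NC(=O)Nc4cc(C(F)(F)F)cc(C(F)(F)F)c4)c3)cc2-c2ccncc2)ccc1Cl` — 894 nM

In a functional assay on TK-10 cells (Homo sapiens) for inhibition, read by sulforhodamine B assay, with a stated time of 48 h (a lower number here means a stronger inhibitor of growth, a higher number a weaker inhibitor of growth), compound 1 gives 2120 nM, the highest of the two numbers; compound 2, which differs from it in several places, gives 894 nM, a gap that lies beyond the scatter. Among the measured compounds shown here, no single-change step between measured compounds is available, so the weight of any one substituent on the terminal urea ring cannot be read from these two alone.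

Compound 3 `O=C(Nc1cccc(-n2cc(-c3ccncc3)c(-c3ccc(Cl)c(O)c3)n2)c1)Nc1ccc(Cl)c(Cl)c1` is not yet measured. It differs from compound 1 by 3,4-dichlorophenyl in place of 3-(trifluoromethyl)phenyl on an amide-type nitrogen. With no measured step of this kind in hand, the expectation for compound 3 in this assay is a step from compound 1 that stays within the scatter, possibly tilting toward a lower number, so a 1.4-fold lower number from compound 1 to compound 3 (0.15 log units; within the scatter) is expected to be small. The value for compound 3 is therefore estimated at 1500 nM, with a range from 500 nM to 4500 nM.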

Compound 3, concentration for 50% growth inhibition: 1910 nM
Compound 3: middle estimate off by 1.3-fold (0.10 log units), on the low side, within the range that was stated.
By their numbers in this assay, from the lowest: compound 2; then compounds 3 and 1 (each within the scatter of the next).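

Among the compounds shown here, this is the first single-change reading at the aryl group on the amide-type nitrogen: in this assay, 3,4-dichlorophenyl in place of 3-(trifluoromethyl)phenyl gives a 1.1-fold lower number from compound 1 to compound 3 (0.05 log units; within the scatter). With the rest of the molecule held fixed, this read-out does not separate the two groups, even though one carries chlorine and the other fluorine. No measurement shown here explains this lack of separation.

On these data alone, whether this position is equally indifferent to a very different group remains open, for example a carboxylic acid or an amine on the phenyl ring in place of the chlorines or the trifluoromethyl. Compound 2 differs from compound 1 and compound 3 in more than one place, so the contribution of each of its changes also remains unresolved.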